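The source may hold more compounds than are shown below. What is called first, only, known or untested is meant among the compounds shown, and "the series" means these compounds.

In an assay on NIH3T3 cells for binding affinity to melatonin receptor type 1A (Homo sapiens) (a higher number here means a weaker inhibitor, a lower number a stronger inhibitor), compound 1 `CCC(=O)NC[C@@H]1CC1c1cccc2oc(CCCCc3ccccc3)cc12` gives 2.1 nM, the lowest number of the three measured. Compound 2 `CC(C)C(=O)NC[C@@H]1CC1c1cccc2oc(CCCCc3ccccc3)cc12` gives 23 nM and compound 3 `O=C(NC[C@@H]1CC1c1cccc2oc(CCCCc3ccccc3)cc12)C1CC1` gives 16 nM. Both measured steps from compound 1 alter only the acyl group: an 11-fold higher number from compound 1 to compound 2 (1.04 log units; beyond the scatter) and a 7.6-fold higher number from compound 1 to compound 3 (0.88 log units; beyond the scatter), while a 1.4-fold lower number from compound 2 to compound 3 (0.16 log units; within the scatter). Compound 4 `CCCC(=O)NCCCc1cccc2oc(CCCCc3ccccc3)cc12` differs from compound 1 by 3-((propylcarbonyl)amino)propyl in place of 2-((propanoylamino)methyl)cyclopropyl on an aromatic carbon. Going by the values given here, no measured step opens the three-membered ring or extends the acyl chain by one carbon, so the two measured steps bear on this change only loosely; both show that altering the acyl group weakened binding in this assay. A weakening step is therefore expected, a 2.9-fold higher number from compound 1 to compound 4 (0.46 log units; beyond the scatter), smaller than those measured. Compound 4 is estimated at 6 nM, with a range from 1.5 nM to 25 nM.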

Compound 4, inhibition constant: 16 nM
Estimate against measurement, compound 4: 2.7-fold (0.43 log units) below; low and high end bracket the measured number.
By their numbers in this assay, from the lowest: compound 1; then compounds 3, 4 and 2 (each within the scatter of the next).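

Opening the ring at this aromatic carbon, with the acyl end also changing, gives a 7.6-fold higher number from compound 1 to compound 4 (0.88 log units; beyond the scatter) in this assay. Going by these compounds alone, earlier steps changed only the acyl group, so this is the first sign that the substituent as a whole matters beyond that end, even with the entering group keeping the same heavy-atom count. No available evidence explains this step.

Ring loss and acyl change sit in one step and cannot be separated here. Also open, on these data alone, is how a propanoyl group on the open propyl chain, or an acetyl group on the cyclopropyl side chain, would compare.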